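The source may report more compounds than this note shows. Statements on the series, on what has been measured and on what is new or still open speak of the compounds shown alone.

Working notes on the series. Going by the values given here, compound 2 (`CCCCOc1ccc2c(N3CCNCC3)cc(=O)oc2c1C`) gives 5030 nM in a functional assay on a cell-free system (plasma, Homo sapiens) for inhibition, with Plasma (Rattus norvegicus) as the target (on this read-out lower numbers stand for stronger inhibition and higher numbers for weaker inhibition), and holds the lowest of the three numbers so far. Compound 3 (`O=c1cc(N2CCNCC2)c2ccc(OCc3cccnc3)cc2o1`) stands higher at 18900 nM on the same read-out, and compound 1 (`O=c1cc(N2CCNCC2)c2ccc(OCc3ccccc3)cc2o1`) higher again at 78800 nM on that read-out. Both differ from compound 2 in more than one place, so neither gap isolates a single change.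

Compound 4 (`Cc1c(OCCOc2ccccc2)ccc2c(N3CCNCC3)cc(=O)oc12`) departs from compound 2 at the end of the chain (phenoxy in place of ethyl on a saturated chain carbon, two bonds along the chain from an oxygen on an aromatic ring), with phenoxy in place of ethyl on a saturated chain carbon, two bonds along the chain from an oxygen on an aromatic ring. Among the compounds with values here, no measured pair compares an alkyl chain end with an aromatic one on a single core. The nearest evidence is a 4.2-fold lower number from compound 1 to compound 3 (0.62 log units; beyond the scatter) for a different swap, and that step is modest. Compound 1 and compound 3 both carry an aromatic ring on the chain and both stand above compound 2, which gives a weak lean upward. A modest rise in this assay is therefore expected, of about the size of that step or smaller, and the expected move is a 2.0-fold higher number from compound 2 to compound 4 (0.30 log units; within the scatter) with the direction uncertain. The estimated value for compound 4 is 10000 nM (expected range 2500 nM to 40000 nM).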

Compound 4, half-maximal inhibitory concentration: 14300 nM
Estimate against measurement, compound 4: 1.4-fold (0.16 log units) below, and the stated range covers the measured number.
By their numbers in this assay, from the lowest: compound 2; then compounds 4 and 3 (each within the scatter of the next); then compound 1.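

At the position on a saturated chain carbon, two bonds along the chain from an oxygen on an aromatic ring, the series now has its first single-place comparison of an alkyl chain end with an aromatic one. In this assay, phenoxy in place of ethyl gives a 2.8-fold higher number from compound 2 to compound 4 (0.45 log units; beyond the scatter) and so turns butyl into 2-phenoxyethyl at a modest cost, with no gain from the larger end on this core. Nothing at hand on the properties of these compounds accounts for the step.

Phenoxy brings a ring, an oxygen and extra length at once, so this one step cannot say which of them sets the rise; a benzyl end or a longer plain chain such as hexyl at the same place would pull these apart. As far as these compounds go, whether an amine such as dimethylamino or a carboxylic acid at the chain end would move the number in the same direction also remains open.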